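The source may hold more compounds than are shown below. What is called first, only, known or untested is meant among the compounds shown, and "the series" means these compounds.

Three compounds share one core. Compound 1 `COC(=O)c1c(O)c2ccccc2n(C)c1=O` carries a methyl on an aromatic nitrogen and a methoxy on a carbonyl carbon; in a functional assay, with a stated time of 20 min, tested at 0.5 mM (a lower number here means a weaker effect, a higher number a stronger effect of the compound at the concentration tested), compound 1 gives 17.5%. Compound 2 `COC(=O)c1c(O)c2ccccc2n(-c2ccccc2)c1=O` carries a phenyl on the aromatic nitrogen instead, and in this assay compound 2 gives 16.8%. Compound 3 `Cn1c(=O)c(C(=O)NCCN)c(O)c2ccccc21` keeps the methyl of compound 1 but carries a (2-aminoethyl)amino in place of the methoxy on the carbonyl carbon; in this assay compound 3 gives 20.9%. That step is a number 3.4 percentage points higher from compound 1 to compound 3 (within the scatter). Among the three numbers the one of compound 3 is the highest, yet its gaps to compound 1 and to compound 2 both lie within the scatter, so no real difference among the three can be claimed.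

Going by the values given here, compound 4 `NCCNC(=O)c1c(O)c2ccccc2n(-c2ccccc2)c1=O` differs from compound 3 in one place. phenyl in place of methyl on an aromatic nitrogen The single measured step that bears on this change is the one from the methyl of compound 1 to the phenyl of compound 2, namely a number 0.7 percentage points lower from compound 1 to compound 2 (within the scatter), which lay within the scatter. The same change, now made on the compound with the (2-aminoethyl)amino group, is therefore expected to give a step of a number 0.9 percentage points lower from compound 3 to compound 4 (within the scatter), nothing beyond the scatter. In this assay compound 4 is estimated at 20%, with a range from 12% to 28%.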

Compound 4, a percentage reported as activity, at one concentration (the size of the read-out at that concentration, not a potency): 1.4%
Compound 4: middle estimate off by 18.6 percentage points, on the high side; measured number below the stated range.
By their numbers in this assay, from the lowest: compound 4; then compounds 2, 1 and 3 (each within the scatter of the next).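

On the core with the (2-aminoethyl)amino group, phenyl in place of methyl on the aromatic nitrogen gives a number 19.5 percentage points lower from compound 3 to compound 4 (beyond the scatter), so a swap that made no readable difference with the methoxy group makes a clear one here: the same change on two cores in this assay, a number 0.7 percentage points lower (within the scatter) from compound 1 to compound 2 and a number 19.5 percentage points lower (beyond the scatter) from compound 3 to compound 4, 18.8 percentage points apart, beyond the scatter of two such steps Seen from the carbonyl carbon, the picture is the same, as (2-aminoethyl)amino in place of methoxy gives a number 15.4 percentage points lower from compound 2 to compound 4 (beyond the scatter) when the phenyl is present, which does not match what this change did with the methyl: the same change on two cores in this assay, a number 3.4 percentage points higher (within the scatter) from compound 1 to compound 3 and a number 15.4 percentage points lower (beyond the scatter) from compound 2 to compound 4, 18.8 percentage points apart, beyond the scatter of two such steps The two places therefore cannot be read one at a time in this assay, since the effect of the group on the aromatic nitrogen depends on the group on the carbonyl carbon, and only the compound carrying both changes brings this out.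

The compounds shown leave open whether a smaller group than phenyl on the aromatic nitrogen, such as ethyl, or a larger one, such as benzyl, would also bring the number down with the (2-aminoethyl)amino group in place. They also leave open whether the amine at the end of the chain matters, which a longer chain or a simple methylamino group on the carbonyl carbon, paired with the phenyl, could test.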